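From 2-Ethoxyethoxy to 4-Fluorophenyl: a Cytotoxicity Outlook

The source may report more compounds than this note shows. Statements on the series, on what has been measured and on what is new or still open speak of the compounds shown alone.

Compound 1 `CCOCCOC(=O)Nc1cc2nc(C3CCCCC3)[nH]c2cc1N(C)C` — > 100 ug/mL
Compound 2 `Cc1ccc(C(=O)Nc2cc3nc(C4CCCCC4)[nH]c3cc2N2CCCC2)cc1` — > 100 ug/mL
Compound 3 `CCOCCOC(=O)Nc1cc2nc(C3CCCCC3)[nH]c2cc1N(CC)CC` — > 100 ug/mL

Of the compounds shown here, three on a shared core have been measured in an ADME assay on Vero cells (Chlorocebus sabaeus) for cytotoxicity, read by resazurin assay, with a stated time of 3 days; on this read-out lower numbers stand for stronger inhibition and higher numbers for weaker inhibition. For compound 1 the result is a limit of the assay, > 100 ug/mL. For compound 2 the result is likewise a limit, > 100 ug/mL. For compound 3 the result is again a limit, > 100 ug/mL. Within the data shown here, the one step between measured compounds that differ in a single place, a step that the two limits leave unreadable from compound 1 to compound 3, therefore cannot be read. What the three values share is that (the limit of > 100 ug/mL in this assay, at which 3 of the 3 values shown sit).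

The step to be followed leads from compound 1 to compound 4 `CN(C)c1cc2[nH]c(C3CCCCC3)nc2cc1NC(=O)c1ccc(F)cc1`: 4-fluorophenyl in place of 2-ethoxyethoxy on a carbonyl carbon. Among the measured compounds shown here, compound 2, which carries a different amide, also sits at the limit, so none of the measured steps gives a readable size to carry over. Compound 4 is therefore expected to stay at or near the limit, with the step that the limit leaves unreadable from compound 1 to compound 4 not beyond the scatter. For compound 4 in this assay the estimate is 150 ug/mL, between 50 ug/mL and 400 ug/mL.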

Compound 4, half-maximal inhibitory concentration: > 100 ug/mL
Compound 4 was reported as a limit; the forecaster's own chance of this, stated with the estimate: 75%; the middle value does not contradict the limit.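

No new step can be read from compound 1 to compound 4, because both results are limits and not numbers: the limit of > 100 ug/mL in this assay, at which 4 of the 4 values shown sit.

The compounds shown leave open how far each lies beyond that limit, and whether any change on the shared core would give a readable value in this assay.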